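Replacing a methylisoxazole with cyclopentyl on a shared core

The source may report more compounds than this note shows. Statements on the series, on what has been measured and on what is new or still open speak of the compounds shown alone.

Compound 1, `CNc1nc2c(-c3ccnc(OC)c3)cnn2cc1C`, gives 1300 nM in an assay on isolated protein for inhibition of activin receptor type-2A (Homo sapiens), read by 33P incorporation, with a stated time of 20 min, in the presence of a further agent that is not named here; on this read-out lower numbers stand for stronger inhibition and higher numbers for weaker inhibition.
Compound 2, `COc1cc(-c2cnn3cc(OC)c(-c4cc(C)no4)nc23)ccn1`, gives 3000 nM in this assay.
Compound 3, `Cn1cc(-c2nc3c(-c4ccnc(OC5CC5)c4)cnn3cc2OCCCC(C)(C)O)cn1`, gives 2900 nM in this assay.

Among these three, compound 2 has the highest number. Its nearest neighbour is compound 3, whose number lies within the usual scatter of compound 2, so the two cannot be ordered. Compound 1 stands further away, with a number beyond the scatter, and is the only one of the three that inhibits more strongly than compound 2 on this read-out.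

Compound 4, `COc1cc(-c2cnn3cc(OC)c(C4CCCC4)nc23)ccn1`, is the untested member of the set. It differs from compound 2 in one place: cyclopentyl in place of 3-methyl-1,2-oxazol-5-yl on an aromatic carbon. Going by the values given here, none of the measured pairs shows a single change, so no measured step guides this one. Without such a reference, the expectation is a step from compound 2 to compound 4 of a 1.2-fold higher number from compound 2 to compound 4 (0.07 log units; within the scatter), that is, no change beyond the scatter in either direction. Compound 4 is therefore estimated at 3500 nM in this assay, with a range from 1200 nM to 10000 nM.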

Compound 4, half-maximal inhibitory concentration: 2900 nM
Beside the measured number, compound 4's estimate is 1.2-fold (0.08 log units) above it; the measured number falls inside the stated range.
By their numbers in this assay, from the lowest: compound 1; then compounds 3, 4 and 2 (each within the scatter of the next).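

In this assay, this first single change in the set gives a 1.0-fold lower number from compound 2 to compound 4 (0.01 log units; within the scatter), so compound 2 and compound 4 cannot be ordered. At this position, next to the ring nitrogen and ortho to a methoxy group, a five-membered aromatic ring with 2 hetero atoms and 2 hydrogen-bond acceptors can thus be exchanged for a five-membered non-aromatic ring of carbon only, with 0 hydrogen-bond acceptors, without a change beyond the scatter. No measurement shown here offers an explanation for this result.

From the compounds shown here alone, it remains open whether a different kind of group at this position, such as an amine, a carboxylic acid or a longer carbon chain, would shift the number beyond the scatter. Going by these compounds, it is also open whether this exchange would read the same if the neighbouring methoxy group were replaced.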